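A few compounds are considered here, and "the series" means these few. Any claim that something is new, unique, unknown or untested is made for them only; others in the source may bear on it.

Compound 1 `CN(C)C(=O)c1cc2cnc(Nc3ccc(NC(=O)C4(C(=O)Nc5ccccc5F)CC4)cc3)nc2n1C1CCCC1`: 70.2%
Compound 2 `CN(C)C(=O)c1cc2cnc(Nc3ccc(NC(=O)C4(C(=O)Nc5ccc(F)cc5)CC4)cc3F)nc2n1C1CCCC1`: 52.3%

Among the measured compounds shown here, in a functional assay on NCI-H1299 cells (Homo sapiens) for inhibition, read by CCK-8 assay, with a stated time of 72 h, tested at 1 uM (a higher number here means more inhibition of growth at the concentration tested, a lower number less inhibition of growth), compound 1 gives 70.2%, the higher of the two numbers measured so far. Compound 2 lies lower, by more than the usual scatter, but it differs from compound 1 in more than one place, so the pair does not isolate any single change.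

Compound 3 `CN(C)C(=O)c1cc2cnc(Nc3ccc(NC(=O)C4(C(=O)Nc5ccccc5)CC4)cc3)nc2n1C1CCCC1` has not yet been measured. Compared with compound 1, it has hydrogen in place of fluoro on an aromatic carbon, ortho to a large group: hydrogen in place of fluoro on an aromatic carbon. For the measured compounds named here, the change is the 2-fluorophenyl to phenyl swap, and no measured pair shows a step of this kind. A step within the scatter is therefore expected, with no firm direction. The estimated change is a number 4.2 percentage points lower from compound 1 to compound 3 (within the scatter). For compound 3, the estimated value in this assay is 66%, with an expected range of 50% to 80%.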

Compound 3, percent growth inhibition at one concentration: 71.2%
For compound 3 the middle estimate is 5.2 percentage points below the measured one; low and high end bracket the measured number.
By their numbers in this assay, from the lowest: compound 2; then compounds 1 and 3 (each within the scatter of the next).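

In this assay, the swap of 2-fluorophenyl to phenyl, on an aromatic carbon ortho to a large group, comes out as a number 1 percentage points higher from compound 1 to compound 3 (within the scatter). This is the first step among the compounds shown that isolates a single change, and it shows that growth inhibition at the concentration tested is retained at this position without the fluoro; compound 1 and compound 2 differ in more than one place and could not show this. No measurement shown here offers an explanation for this step.

The compounds shown leave open whether a larger group at this position, such as a chloro, a methyl or a methoxy, or an amine, would also retain growth inhibition. Among the compounds shown here, no single-place step reaches compound 2, and the contribution of each change that sets it apart remains unresolved.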